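Chloro to fluoro on the aryl ring: compound 4 outlook

The source may report more compounds than this note shows. Statements on the series, on what has been measured and on what is new or still open speak of the compounds shown alone.

Measured so far:
compound 1 `Cn1nc(-c2ccccc2F)n(C)c1=S` 0.23 mg/kg
compound 2 `Cn1nc(-c2ccc(Cl)cc2)n(C)c1=S` 0.27 mg/kg
compound 3 `CCCn1c(-c2ccc(Cl)cc2)nn(C)c1=S` 12.5 mg/kg

Compound 2 stands second highest of the three numbers in a functional assay on the whole organism with Mus musculus as the target; a lower number here means that less compound is needed, a higher number that more compound is needed for the effect. Its nearest neighbour is compound 1, whose number is within the scatter of that of compound 2, so no order between the two is claimed. For the measured compounds named here, compound 3 lies far off: a 46-fold higher number from compound 2 to compound 3 (1.67 log units; beyond the scatter) is the one large step seen, and it concerns the chain on the aromatic nitrogen, not the aryl ring.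

The step to the unmeasured compound 4 `Cn1nc(-c2ccc(F)cc2)n(C)c1=S` is fluoro in place of chloro on an aromatic carbon. Going by the values given here, no measured pair alters only this substituent, so the step has no direct precedent. Among the compounds with values here, the only hint is that compound 1, which carries fluoro on its ring, and compound 2, which carries chloro, give numbers within the scatter of each other. On this basis no step beyond the scatter is expected in this assay; the expected step of a 1.1-fold higher number from compound 2 to compound 4 (0.05 log units; within the scatter) is small. Compound 4 is estimated at 0.3 mg/kg, with a range of 0.12 mg/kg to 0.8 mg/kg. On these data alone, a wider spread than usual is allowed for, since the change is untested.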

Compound 4, dose for half-maximal effect: 1 mg/kg
The estimate for compound 4 lay 3.3-fold (0.52 log units) below the measured number; measured number outside the range, above it.
By their numbers in this assay, from the lowest: compounds 1 and 2 (each within the scatter of the next); then compound 4; then compound 3.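

In this assay, for the compounds shown here, the aromatic carbon para to a group of 8 heavy atoms is not indifferent to the halogen it carries: fluoro in place of chloro gives a 3.7-fold higher number from compound 2 to compound 4 (0.57 log units; beyond the scatter) and so moves the number beyond the scatter, which no earlier pair could show for this change alone. This step is modest, while a 46-fold higher number from compound 2 to compound 3 (1.67 log units; beyond the scatter) remains large, so of the two changes read from compound 2, the one on the chain at the aromatic nitrogen still has the greater reach, yet the aryl substituent can no longer be set aside as a silent position. Nothing measured on these compounds bears on the reason for the fluoro step.

The compounds shown leave open whether the number at this place follows the halogen series, since bromo, iodo, methoxy, an amine or plain hydrogen do not appear among them. They also leave open whether fluoro in place of chloro would have a step of similar size on the longer chain of compound 3, or whether the two changes would act independently.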